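Swapping chloro for ethoxy on compound 3

This account rests on a few compounds, and the source may have more. Where it says the series, first, only, none or still open, it means among the compounds named here.

Compound 1 `COc1ccc(-c2c(C(=O)c3cc(OC)c(OC)c(OC)c3)sc3ccccc23)c(OC)c1`: 3900 nM
Compound 2 `COc1ccc(OC)c(-c2c(C(=O)c3cc(OC)c(OC)c(OC)c3)sc3ccccc23)c1`: 10000 nM
Compound 3 `COc1cc(C(=O)c2sc3ccccc3c2Nc2ccc(Cl)cc2)cc(OC)c1OC`: 3700 nM

All three values come from a functional assay on HeLa cells (Homo sapiens) for antiproliferative activity, read by MTT assay, with a stated time of 72 h; on this read-out lower numbers stand for stronger inhibition and higher numbers for weaker inhibition. Compound 3 stands level with compound 1, as a 1.1-fold lower number from compound 1 to compound 3 (0.02 log units; within the scatter) shows, and clearly ahead of compound 2, as a 2.7-fold lower number from compound 2 to compound 3 (0.43 log units; beyond the scatter) shows.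

Compound 4 `CCOc1ccc(Nc2c(C(=O)c3cc(OC)c(OC)c(OC)c3)sc3ccccc23)cc1` differs from compound 3 in one place: ethoxy in place of chloro on an aromatic carbon. This puts ethoxy in place of chloro on an aromatic carbon, para to a large group, turning (4-chlorophenyl)amino into (4-ethoxyphenyl)amino.

Within the data shown here, no measured pair makes this exact swap, so the evidence is indirect. Moving the methoxy groups on one ring gave a 2.6-fold higher number from compound 1 to compound 2 (0.41 log units; beyond the scatter), a modest step. Replacing that whole aryl group gave steps no larger, the two already cited. These small steps suggest a small change here too, though they do not settle its direction. The expected step is a 1.5-fold lower number from compound 3 to compound 4 (0.17 log units; within the scatter), and a larger move cannot be ruled out.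

For compound 4 the estimated value is 2500 nM, with an expected range from 400 nM to 9000 nM.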

Compound 4, half-maximal inhibitory concentration: 700 nM
Compound 4: middle estimate off by 3.6-fold (0.55 log units), on the high side, within the range that was stated.
By their numbers in this assay, from the lowest: compound 4; then compounds 3 and 1 (each within the scatter of the next); then compound 2.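

Among these compounds, the position para to a large group on this ring matters more than the earlier compounds could show: ethoxy in place of chloro gives a 5.3-fold lower number from compound 3 to compound 4 (0.72 log units; beyond the scatter), a larger step than any among compounds 1, 2 and 3 in this assay. Compound 3 stood only level with compound 1, yet with this one group changed the amino-linked series moves clear of both dimethoxyphenyl compounds, with a 5.6-fold lower number from compound 1 to compound 4 (0.75 log units; beyond the scatter) and a 14-fold lower number from compound 2 to compound 4 (1.15 log units; beyond the scatter), which makes compound 4 the strongest of the four here. No measurement at hand explains why ethoxy outperforms chloro at this position.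

The compounds shown leave open whether the oxygen or the two-carbon chain carries the gain. Methoxy, a longer chain such as propoxy, or an amine such as dimethylamino at this position would begin to separate these possibilities.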